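Sulfonamide nitrogen substituents in the aortic series

A few compounds are considered here, and "the series" means these few. Any claim that something is new, unique, unknown or untested is made for them only; others in the source may bear on it.

Compound 2 `CCNS(=O)(=O)c1ccc2c(c1)C(n1ccccc1=O)=CC(C)(C)O2` sits in the middle of the three values in a functional assay on the whole organism (aorta) with Rattus norvegicus as the target (a higher number here means a larger maximal response, a lower number a smaller maximal response), where compound 2 gives 72.4%; all three numbers lie within the scatter of one another. Compound 1 `CC1(C)C=C(n2ccccc2=O)c2cc(S(N)(=O)=O)ccc2O1` gives 77.5% and compound 3 `CC1(C)C=C(n2ccccc2=O)c2cc(S(=O)(=O)NCc3ccccc3)ccc2O1` gives 71.1%; the steps of a number 5.1 percentage points lower from compound 1 to compound 2 (within the scatter), a number 6.4 percentage points lower from compound 1 to compound 3 (within the scatter) and a number 1.3 percentage points lower from compound 2 to compound 3 (within the scatter) all stay within the scatter. Compound 4 `CC1(C)C=C(n2ccccc2=O)c2cc(S(=O)(=O)NC(=O)Nc3ccccc3)ccc2O1` differs from compound 2 by phenylcarbamoyl in place of ethyl on a sulfonamide nitrogen. Every measured step changes the group on the sulfonamide nitrogen, and none moved this assay beyond the scatter, so the step of a number 0.4 percentage points lower from compound 2 to compound 4 (within the scatter) is expected to stay within the scatter as well. Compound 4 is estimated at 72%, in the range 58% to 86%.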

Compound 4, largest response reached (Emax), in percent of the reference or control that the assay uses: 90.8%
Compound 4: middle estimate off by 18.8 percentage points, on the low side, outside the stated range (above it).
By their numbers in this assay, from the lowest: compounds 3, 2 and 1 (each within the scatter of the next); then compound 4.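

Among these compounds, the sulfonamide nitrogen is not silent in this assay: phenylcarbamoyl is the first group here to move the number beyond the scatter, against ethyl (a number 18.4 percentage points higher from compound 2 to compound 4 (beyond the scatter)), benzyl (a number 19.7 percentage points higher from compound 3 to compound 4 (beyond the scatter)) and hydrogen (a number 13.3 percentage points higher from compound 1 to compound 4 (beyond the scatter)). Benzyl also carries a six-membered aromatic ring, yet compound 3 stays within the scatter of compound 2, so that ring alone does not accompany a rise. No evidence on hand bears on this result. Open, from the compounds shown here alone, is whether the carbonyl or the whole phenylcarbamoyl group goes with the rise; acetyl or methylcarbamoyl on this nitrogen would separate the two.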